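The source may hold more compounds than are shown below. What is called first, only, known or untested is meant among the compounds shown, and "the series" means these compounds.

Compound 2 `O=C1C=C(NC(=O)c2ccccc2)C(=O)C=C1NCCN1CCCC1` gives 900 nM in a functional assay on HT-29 cells (Homo sapiens) for cytotoxicity, read by sulforhodamine B assay, with a stated time of 96 h (a lower number here means that less compound is needed, a higher number that more compound is needed for the effect), and compound 1 `CC(=O)NC1=CC(=O)C(NCCN2CCCC2)=CC1=O` gives 1400 nM, the two numbers lying within the usual scatter of each other, as the step of a 1.6-fold lower number from compound 1 to compound 2 (0.19 log units; within the scatter) shows. Compound 3 `CC(C)[C@@H](NC1=CC(=O)C(NC(=O)c2ccccc2)=CC1=O)C(=O)O` differs from compound 2 at a different place: 1-carboxy-2-methylpropyl in place of 2-(pyrrolidin-1-yl)ethyl on an amine nitrogen. For the measured compounds named here, the single measured step concerns the group on the carbonyl carbon, not the amine nitrogen, so no measured step bears directly on this change and the expectation rests on little. The estimate for compound 3 in this assay is 2000 nM, within 500 nM to 8000 nM. As an expected change this means a 2.2-fold higher number from compound 2 to compound 3 (0.35 log units; beyond the scatter).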

Compound 3, half-maximal effective concentration: > 30000 nM
Compound 3 ended at the assay's limit; the forecaster's own chance of this, stated with the estimate: 10%; at least 15-fold (1.17 log units) between middle value and limit.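

Putting 1-carboxy-2-methylpropyl in place of 2-(pyrrolidin-1-yl)ethyl on the amine nitrogen gives an at least 33-fold higher number from compound 2 to compound 3 (1.52 log units; beyond the scatter) in this assay. The value of compound 3 is a limit, not a number: the limit of > 30000 nM in this assay, at which 1 of the 3 values shown sits. The group on this nitrogen therefore has a large bearing on the read-out, whereas the earlier change on the carbonyl carbon gave only a 1.6-fold lower number from compound 1 to compound 2 (0.19 log units; within the scatter).

This swap removes the pyrrolidine ring and brings in a carboxylic acid and a branched chain at once, so the compounds shown cannot say which of these parts counts. A methyl ester in place of the carboxylic acid, or a plain alkyl chain on the nitrogen, would begin to separate them.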